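A few compounds are considered here, and "the series" means these few. Any claim that something is new, unique, unknown or untested is made for them only; others in the source may bear on it.

Measured so far in a functional assay on MDA-MB-231 cells (Homo sapiens) for cytotoxicity, read by MTT assay, with a stated time of 48 h (on this read-out higher numbers stand for weaker inhibition and lower numbers for stronger inhibition), as follows
compound 1 `COc1ccc(C2=NOC(COc3ccc(-c4nnnn4-c4cc(OC)c(OC)c(OC)c4)cc3N)C2)cc1OC` gives 3570 nM
compound 2 `COc1cc(C2=NOC(COc3ccc(-c4nnnn4-c4cc(OC)c(OC)c(OC)c4)cc3N)C2)cc(OC)c1OC` gives 3230 nM
compound 3 `COc1ccc(C2=NOC(COc3ccc(-c4nnnn4-c4cc(OC)c(OC)c(OC)c4)cc3N)C2)cc1[N+](=O)[O-]` gives 3560 nM

Compound 3, at 3560 nM in this assay, cannot be told apart from the other two. The steps are a 1.0-fold lower number from compound 1 to compound 3 (0.00 log units; within the scatter) and a 1.1-fold higher number from compound 2 to compound 3 (0.04 log units; within the scatter) and both lie within the scatter.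

The next comparison is compound 4 `COc1cc(-n2nnnc2-c2ccc(OCC3CC(c4cccc(Cl)c4)=NO3)c(N)c2)cc(OC)c1OC`, which puts 3-chlorophenyl in place of 4-methoxy-3-nitrophenyl on a carbon with a double bond to nitrogen and leaves the rest of the structure unchanged.

The closest evidence is the set of changes at this same place, namely a 1.1-fold higher number from compound 2 to compound 3 (0.04 log units; within the scatter) and a 1.1-fold lower number from compound 1 to compound 2 (0.04 log units; within the scatter), which moved nothing beyond the scatter. Within the data shown here, no measured compound carries chlorine, so this reading is an extrapolation from three compounds. No step beyond the scatter is expected in this assay, and the estimated step is a 1.1-fold lower number from compound 3 to compound 4 (0.03 log units; within the scatter) in that assay. Compound 4 is expected at 3300 nM in this series. The estimated range runs from 1500 nM to 7000 nM for this measurement.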

Compound 4, half-maximal inhibitory concentration: 2180 nM
Compound 4: middle estimate off by 1.5-fold (0.18 log units), on the high side, within the range that was stated.
By their numbers in this assay, from the lowest: compounds 4, 2, 3 and 1 (each within the scatter of the next).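

In this assay the change to 3-chlorophenyl on the carbon with a double bond to nitrogen gives a 1.6-fold lower number from compound 3 to compound 4 (0.21 log units; within the scatter) and a 1.5-fold lower number from compound 2 to compound 4 (0.17 log units; within the scatter) and a 1.6-fold lower number from compound 1 to compound 4 (0.21 log units; within the scatter) and all three steps stay within the scatter. This position therefore accepts a chlorine-bearing phenyl with no hydrogen-bond acceptors as well as the methoxy and nitro groups of the earlier compounds, with no step beyond the scatter, so those acceptors are not shown to be needed here. Nothing available explains any of these numbers.

Still open, going by these compounds, is whether any group at this position gives a step beyond the scatter, for example an aminophenyl, a carboxyphenyl or a cyclohexyl. Also open, on these data alone, is how 4-chlorophenyl would compare with 3-chlorophenyl.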